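N-Methylation of the glycinamide in a nitro-sulfone series

A few compounds are considered here, and "the series" means these few. Any claim that something is new, unique, unknown or untested is made for them only; others in the source may bear on it.

Measured compounds:
compound 1, `CN(Cc1cccc(F)c1)C(=O)CCCNC(=O)c1ccc(S(C)(=O)=O)c([N+](=O)[O-])c1`: > 27000 nM
compound 2, `CS(=O)(=O)c1ccc(C(=O)NCC(=O)N(Cc2ccccc2)Cc2ccccc2)cc1[N+](=O)[O-]`: 11900 nM

In an ADME assay on HepG2 cells (Homo sapiens) for cytotoxicity, read by CellTiter-Glo and ATP content, with a stated time of 72 h (on this read-out lower numbers stand for an effect already at smaller amounts and higher numbers for an effect only at larger amounts of compound), compound 2 gives 11900 nM. Compound 1 gives only a limit in this assay, > 27000 nM, so no number is known for it. Among the two results shown, compound 2 thus holds the only number, while the other result, that of compound 1, is a limit (the limit of > 27000 nM in this assay, at which 1 of the 2 values shown sits).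

Compound 3, `CN(CC(=O)N(Cc1ccccc1)Cc1ccccc1)C(=O)c1ccc(S(C)(=O)=O)c([N+](=O)[O-])c1`, has not yet been measured in this assay. It differs from compound 2 in one place: methyl in place of hydrogen on an amide-type nitrogen. For the measured compounds named here, no measured pair in this set shows a change of this kind, so the size of the step can only be expected, not read off. A single methyl on the amide-type nitrogen is a small alteration, and the step is expected to stay within the usual scatter, in no particular direction. Compound 3 is therefore estimated at 12000 nM, with a range from 5000 nM to 30000 nM, which corresponds to an expected step of a 1.0-fold higher number from compound 2 to compound 3 (0.00 log units; within the scatter).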

Compound 3, half-maximal effective concentration: > 27000 nM
Compound 3 ended at the assay's limit; the forecaster's own chance of this, stated with the estimate: 30%; middle value at least 2.2-fold (0.35 log units) away from the limit.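

In this assay, methyl in place of hydrogen on an amide-type nitrogen, whose other neighbours are the carbonyl carbon and a saturated chain carbon, gives an at least 2.2-fold higher number from compound 2 to compound 3 (0.35 log units; beyond the scatter). For the compounds shown here, this is the first step in the set that can be read, and it shows that this position is not indifferent to a single added carbon: the amide hydrogen cannot be replaced by methyl without a change beyond the scatter in this read-out. The size of the change has only a lower bound, as compound 3 carries a limit of the assay and not a number, and the results shown now gather at that limit: the limit of > 27000 nM in this assay, at which 2 of the 3 values shown sit.

The compounds shown leave open whether an ethyl group or a longer chain on this nitrogen goes the same way as methyl, and whether an amine or a carboxylic acid at the end of such a chain would bring the result back into the measurable range. They also do not tell how far past the limit compound 3 lies, and compound 1 differs from it in more than one place, so it offers no comparison.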